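Amide-linked analogue of a triazole thioether series

The compounds below may be only part of what the source reports. "The series", "measured", "known", "first", "only" and "open" are said of these compounds alone.

Compound 3 `COc1ccc(CSc2nnc(-c3cc(OC)c(OC)c(OC)c3)n2-c2ccc(N(C)C)cc2)cc1` stands at the lowest number among the two plain values in a functional assay on HCT-116 cells (Homo sapiens) for inhibition, read by MTT assay, with a stated time of 48 h (on this read-out higher numbers stand for weaker inhibition and lower numbers for stronger inhibition), giving 1150 nM. Compound 1 `COc1ccc(CSc2nnc(-c3cc(OC)c(OC)c(OC)c3)n2-c2ccc(OC)cc2)cc1` gives 49600 nM in this assay, so the change of a 43-fold lower number from compound 1 to compound 3 (1.63 log units; beyond the scatter) is large. Compound 2 `COc1ccc(-n2c(SCC(=O)c3ccc(F)cc3)nnc2-c2cc(OC)c(OC)c(OC)c2)cc1` reaches only a limit of this assay, > 60000 nM, and the limit of > 60000 nM in this assay, at which 1 of the 3 values shown sits, marks that it is a limit and not a number. Among the measured compounds shown here, the step of an at least 1.2-fold higher number from compound 1 to compound 2 (0.08 log units; that floor lies within the scatter) is the only measured change on a saturated chain carbon bound to a sulfur, and it did not lower the number.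

Compound 4 `COc1ccc(NC(=O)CSc2nnc(-c3cc(OC)c(OC)c(OC)c3)n2-c2ccc(N(C)C)cc2)cc1` is not yet measured. It differs from compound 3 by (4-methoxyphenyl)carbamoyl in place of 4-methoxyphenyl on a saturated chain carbon bound to a sulfur. For the measured compounds named here, the one comparable step, an at least 1.2-fold higher number from compound 1 to compound 2 (0.08 log units; that floor lies within the scatter), bears on this change, since both replace the aryl on that chain carbon with a carbonyl-bearing group; it gave no gain and its true size is hidden behind a limit. A weaker result for compound 4 is therefore expected, with a 4.3-fold higher number from compound 3 to compound 4 (0.64 log units; beyond the scatter) as the estimated step. Compound 4 is expected to give about 5000 nM in this assay, within the range 1500 nM to 20000 nM.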

Compound 4, half-maximal inhibitory concentration: > 60000 nM
Compound 4: a limit, no number; the forecaster's own chance of this, stated with the estimate: 10%; at least 12-fold (1.07 log units) between middle value and limit.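

At the saturated chain carbon bound to a sulfur, (4-methoxyphenyl)carbamoyl in place of 4-methoxyphenyl gives an at least 52-fold higher number from compound 3 to compound 4 (1.71 log units; beyond the scatter) in this assay, a loss beyond the scatter that the earlier step at this place, an at least 1.2-fold higher number from compound 1 to compound 2 (0.08 log units; that floor lies within the scatter), could not show. Compound 4 keeps the dimethylamino group of compound 3, so that group does not preserve the lower number once this change is made. Compound 4 reaches a limit of the assay and not a number, and its limit is the one compound 2 also reaches: the limit of > 60000 nM in this assay, at which 2 of the 4 values shown sit.

As far as these compounds go, the true size of the loss stays open, as does whether the amide hydrogen or the carbonyl matters more. From the compounds shown here alone, it is also open whether a carboxylic acid, an amine or a longer chain on this chain carbon would keep the number near that of compound 3.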